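Cytotoxicity notes: pyrimidinyl to methylpyrazolyl exchange

The compounds below may be only part of what the source reports. "The series", "measured", "known", "first", "only" and "open" are said of these compounds alone.

Three measured compounds and one awaiting measurement share the same fused core. In an ADME assay on Huh-7 cells (Homo sapiens) for cytotoxicity, read by MTT assay, with a stated time of 48 h (a lower number here means that less compound is tolerated, a higher number that more compound is tolerated), compound 1 `CN(C)CCCCN(C(=O)O)c1ccc(Cn2nc(-c3ccc(F)cc3)c3ccccc3c2=O)cc1` gives 19000 nM. In this assay compound 2 `CN(C)CCCCN(C(=O)O)c1ccc(N2N=C(c3ccc(F)cc3)C3C=CC=CC3C2=O)cc1` gives 21800 nM. In this assay compound 3 `CN(C)CCCCOC(=O)Nc1ccc(Cn2nc(-c3cncnc3)c3ccccc3c2=O)cc1` gives 65300 nM, the highest of the three numbers; its nearest neighbour is compound 2 and its furthest compound 1, and both gaps lie beyond the usual scatter. Compound 3 thus sits at the tolerated end of what has been measured.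

Compound 4 `CN(C)CCCCOC(=O)Nc1ccc(Cn2nc(-c3cnn(C)c3)c3ccccc3c2=O)cc1` differs from compound 3 in one place: 1-methyl-1H-pyrazol-4-yl in place of pyrimidin-5-yl on an aromatic carbon. Among the measured compounds shown here, no step between two measured compounds isolates this kind of exchange, so the series gives no direct size for it. The two groups match in what is counted, and the rest of the molecule is identical. Compound 4 is expected to stay close to compound 3 because compound 3 gives 65300 nM and nothing else is altered. Measured against compound 3, a 1.2-fold lower number from compound 3 to compound 4 (0.07 log units; within the scatter) is expected to remain within the scatter. The estimate for compound 4 is 55000 nM, with a range from 25000 nM to 120000 nM.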

Compound 4, half-maximal cytotoxic concentration: 55900 nM
Compound 4: the middle estimate sits 1.0-fold (0.01 log units) below what was measured; measured number inside the range.
By their numbers in this assay, from the lowest: compounds 1 and 2 (each within the scatter of the next); then compounds 4 and 3 (each within the scatter of the next).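

At the aromatic carbon ortho to a fused ring, 1-methyl-1H-pyrazol-4-yl in place of pyrimidin-5-yl gives a 1.2-fold lower number from compound 3 to compound 4 (0.07 log units; within the scatter) in this assay and so supplies the only direct size for this exchange in the series. A five-membered aromatic ring thus stands in for a six-membered one at this position, with the same counted heavy atoms, donors and acceptors, and the number stays within the scatter. Nothing measured explains why the number holds.

On these data alone, whether this tolerance extends to an amine, a carboxylic acid or a longer alkyl chain on this aromatic carbon remains open, as does the outcome for the pyrazol-4-yl ring without its methyl. Whether the exchange stays this small with a different chain on the carbamate is also unsettled.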